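Cytotoxicity notes: bromobenzamide series, methoxy removal

The source may report more compounds than this note shows. Statements on the series, on what has been measured and on what is new or still open speak of the compounds shown alone.

Measured so far:
Compound 1 `O=C(Nc1ccccc1)c1cc(Br)cc(Br)c1` — > 100000 nM
Compound 2 `COc1ccc(Br)cc1C(=O)Nc1ccc(Sc2nc3ccccc3s2)cc1` — > 100000 nM
Compound 3 `COc1ccccc1C(=O)Nc1ccccc1` — > 100000 nM

In an ADME assay on HEK293 cells (Homo sapiens) for cytotoxicity, read by reporter gene assay and resazurin assay, with a stated time of 48 h (a lower number here means that less compound is tolerated, a higher number that more compound is tolerated), every value recorded for this small set is a limit of the assay rather than a number: the limit of > 100000 nM in this assay, at which 3 of the 3 values shown sit. Within the data shown here, compound 2 therefore stands at the limit, and the two other compounds stand at the same limit, so no ordering among them can be drawn and no step between measured compounds is available.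

Compound 4 `O=C(Nc1ccc(Sc2nc3ccccc3s2)cc1)c1cccc(Br)c1` is the next compound to be measured. It differs from compound 2 in one place: hydrogen in place of methoxy on an aromatic carbon. The change is small, so in this assay the step is expected to be none beyond the scatter, a step that the limit leaves unreadable from compound 2 to compound 4, with compound 4 expected to remain at the limit because all three recorded values already sit there: the limit of > 100000 nM in this assay, at which 3 of the 3 values shown sit. Compound 4 is thus estimated at 150000 nM, with an expected range from 50000 nM to 500000 nM, and the most likely outcome is again a limit rather than a number.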

Compound 4, half-maximal cytotoxic concentration: 74000 nM
Compound 4: middle estimate off by 2.0-fold (0.31 log units), on the high side; the range from low to high includes it.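

In this assay, among these compounds, compound 4 gives 74000 nM, the first value in this set that is a number rather than a limit. Compound 2 gives > 100000 nM, which is a limit, so hydrogen in place of methoxy on this aromatic carbon, ortho to a large group and para to a bromo group, can be read only as an at least 1.3-fold lower number from compound 2 to compound 4 (0.13 log units; that floor lies within the scatter). The full size of this step stays unknown, because the other end of it is not a number: the limit of > 100000 nM in this assay, at which 3 of the 4 values shown sit.

The compounds shown leave open how an amine or an ethoxy group on this carbon would read in this assay. They also leave open whether the number for compound 4 holds when the bromo group gives way to hydrogen.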